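Chloro-to-fluoro exchange on the carbamate side of the series

The compounds below may be only part of what the source reports. "The series", "measured", "known", "first", "only" and "open" are said of these compounds alone.

Two compounds have been measured in a functional assay on CHO cells for antagonist activity at metabotropic glutamate receptor 5 (Homo sapiens), read by calcium flux; on this read-out higher numbers stand for weaker inhibition and lower numbers for stronger inhibition:

Compound 1 `Cc1c(C(C)OC(=O)Nc2ccccc2)oc2ncnn12`: 63.1 nM
Compound 2 `Cc1c(C(C)OC(=O)Nc2cccc(Cl)c2)oc2ncnn12`: 39.8 nM

Compound 2 carries the lower of the two numbers shown, but the step of a 1.6-fold lower number from compound 1 to compound 2 (0.20 log units; within the scatter) is within the scatter, so no order between compound 1 and compound 2 is claimed.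

Compound 3 `Cc1c(C(C)OC(=O)Nc2cccc(F)c2)oc2ncnn12` differs from compound 2 by fluoro in place of chloro on an aromatic carbon. Among the compounds with values here, the one measured step, a 1.6-fold lower number from compound 1 to compound 2 (0.20 log units; within the scatter), concerns chloro against hydrogen at this carbon and stayed within the scatter; no fluoro comparison exists. The step of a 1.3-fold higher number from compound 2 to compound 3 (0.10 log units; within the scatter) is therefore expected to remain within the scatter, in either direction. Compound 3 is estimated at 50 nM, with a range from 20 nM to 125 nM.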

Compound 3, half-maximal inhibitory concentration in the metabotropic glutamate receptor 5 assay: 50.1 nM
Beside the measured number, compound 3's estimate is 1.0-fold (0.00 log units) below it, and the stated range covers the measured number.
By their numbers in the metabotropic glutamate receptor 5 assay, from the lowest: compounds 2, 3 and 1 (each within the scatter of the next).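

In the metabotropic glutamate receptor 5 assay, compound 3 gives 50.1 nM, and the steps of a 1.3-fold higher number from compound 2 to compound 3 (0.10 log units; within the scatter) and a 1.3-fold lower number from compound 1 to compound 3 (0.10 log units; within the scatter) leave fluoro, chloro and hydrogen at this carbon without a readable separation, so the earlier null result for chloro now extends to a second halogen. In a physicochemical assay for lipophilicity, at pH 7.4 (a lower number here means a more polar compound, a higher number a more lipophilic compound), compound 2 gives 2.9 and compound 3 gives 2.6; the exchange gives a number 0.30 log units lower from compound 2 to compound 3 (within the scatter) and so also stays unresolved. Nothing available accounts for these readings.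

Open, on these data alone, is whether a different kind of group at this carbon, such as an amine, a carboxylic acid or a methoxy, would separate from these three compounds in the metabotropic glutamate receptor 5 assay at all.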